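The compounds below may be only part of what the source reports. "The series", "measured", "known", "first", "only" and "open" are said of these compounds alone.

In a functional assay on K562 cells (Homo sapiens) for cytotoxicity, read by MTT assay, with a stated time of 24 h (a higher number here means a weaker inhibitor, a lower number a stronger inhibitor), compound 1 (`COc1cc(/C=C2\CN(C)C/C(=C\c3ccccc3F)C2=O)cc(OC)c1OC`) gives 4340 nM as a measured number. For compound 2 (`COc1cc(/C=C2\CN(C)C/C(=C\c3ccc(Cl)cc3)C2=O)cc(OC)c1OC`) the reading > 20000 nM is a limit and not a number. Compound 3 (`COc1cc(/C=C2\CN(C)C/C(=C\c3ccc(Cl)cc3Cl)C2=O)cc(OC)c1OC`) turns 4-chlorophenyl into 2,4-dichlorophenyl, with chloro in place of hydrogen on an aromatic carbon as the difference: chloro in place of hydrogen on an aromatic carbon. For the measured compounds named here, one measured step bears on this: an at least 4.6-fold higher number from compound 1 to compound 2 (0.66 log units; beyond the scatter) when 4-chlorophenyl replaced 2-fluorophenyl. Compound 1 carries that 2-fluorophenyl and gives 4340 nM as its reading, so a modest move to a lower number is expected, though with wide uncertainty. The expected change is an at least 1.6-fold lower number from compound 2 to compound 3 (0.22 log units; that floor lies within the scatter) in this direction. Compound 3 is estimated at 12000 nM with 4000 nM to 25000 nM as the expected range.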

Compound 3, half-maximal inhibitory concentration: > 20000 nM
Compound 3 ended at the assay's limit; the forecaster's own chance of this, stated with the estimate: 40%; middle value at least 1.6-fold (0.22 log units) from the limit.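

With chloro added on the aromatic carbon ortho to a large group, the reading in this assay still does not come below the limit, so this added chloro does not recover a measurable number. Replacing 2-fluorophenyl with 2,4-dichlorophenyl gives an at least 4.6-fold higher number from compound 1 to compound 3 (0.66 log units; beyond the scatter). Any effect of the added chloro itself cannot be read, because compound 2 and compound 3 both sit at the limit: the limit of > 20000 nM in this assay, at which 2 of the 3 values shown sit.

As far as these compounds go, it remains open whether the chloro of 4-chlorophenyl accounts for the gap from compound 1. From the compounds shown here alone, how an amine or a carboxylic acid on this aromatic carbon would read is also open.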